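Pyridine to pyrimidine amide on the dimethylamino analogue

This account rests on a few compounds, and the source may have more. Where it says the series, first, only, none or still open, it means among the compounds named here.

Compound 2 `COc1cc(N(C)C)c(NC(=O)c2ccccn2)cc1Nc1nccc(-c2cn(C)c3ccccc23)n1` gives the higher of the two numbers in a functional assay on NCI-H1975 cells (Homo sapiens) for antiproliferative activity, read by MTT assay, with a stated time of 72 h (a higher number here means a weaker inhibitor, a lower number a stronger inhibitor), with 10400 nM. Compound 1 `COc1cc(N(C)CCN(C)C)c(NC(=O)c2ncccn2)cc1Nc1nccc(-c2cn(C)c3ccccc23)n1` differs from it in two places and gives 650 nM in this assay. Compound 3 `COc1cc(N(C)C)c(NC(=O)c2ncccn2)cc1Nc1nccc(-c2cn(C)c3ccccc23)n1` is not yet measured; it carries pyrimidin-2-yl in place of pyridin-2-yl on a carbonyl carbon. For the measured compounds named here, no single-change step is available to size this exchange, so the expectation rests on the spread between the two measured compounds. A step toward a lower number, beyond the scatter, is expected from compound 2 to compound 3, a 3.5-fold lower number from compound 2 to compound 3 (0.54 log units; beyond the scatter). For compound 3 the estimate in this assay is 3000 nM, within 1000 nM to 9000 nM.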

Compound 3, half-maximal inhibitory concentration: 5400 nM
For compound 3 the middle estimate is 1.8-fold (0.26 log units) below the measured one; measured number inside the range.
By their numbers in this assay, from the lowest: compound 1; then compounds 3 and 2 (each within the scatter of the next).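

In this assay, pyrimidin-2-yl in place of pyridin-2-yl on a carbonyl carbon gives a 1.9-fold lower number from compound 2 to compound 3 (0.28 log units; within the scatter) and so does not separate the two amides. The chain carries the larger effect: hydrogen in place of (dimethylamino)methyl on a saturated chain carbon bound to a nitrogen on an aromatic ring gives an 8.3-fold higher number from compound 1 to compound 3 (0.92 log units; beyond the scatter) and stands beyond the scatter. Nothing on hand bears on the cause of either step.

Still open, as far as these compounds go, is whether a morpholine or piperazine at the chain end would keep that step, and whether pyridin-2-yl on the carbonyl carbon reads the same with the (dimethylamino)methyl chain present.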